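This account rests on a few compounds, and the source may have more. Where it says the series, first, only, none or still open, it means among the compounds named here.

Compound 2 `Cc1ccc2c(c1)[n+]([O-])c(NCCN1CCCCC1)n[n+]2[O-]` holds the higher of the two numbers in a physicochemical assay for solubility, in the presence of a further agent that is not named here; on this read-out lower numbers stand for lower solubility and higher numbers for higher solubility: compound 2 gives 45000000 nM, whereas compound 1 `CCCN(CCC)CCNc1n[n+]([O-])c2ccc(Cl)cc2[n+]1[O-]` gives 600000 nM, a gap beyond the scatter. Compound 1 and compound 2 differ in two places, so their values show only that much. Compound 3 `CCCN(CCC)CCNc1n[n+]([O-])c2ccc(C)cc2[n+]1[O-]` differs from compound 2 in one place: dipropylamino in place of piperidin-1-yl on a saturated chain carbon, two bonds along the chain from a nitrogen on an aromatic ring. Within the data shown here, no step of this kind has been measured. Compound 3 is expected to come out lower in this assay, the estimated step being a 4.5-fold lower number from compound 2 to compound 3 (0.65 log units; beyond the scatter). In this assay compound 3 is expected to give 10000000 nM, within 1500000 nM to 45000000 nM.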

Compound 3, solubility: 38000000 nM
The estimate for compound 3 lay 3.8-fold (0.58 log units) below the measured number, within the range that was stated.
By their numbers in this assay, from the lowest: compound 1; then compounds 3 and 2 (each within the scatter of the next).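

In this assay dipropylamino in place of piperidin-1-yl on the saturated chain carbon shows a 1.2-fold lower number from compound 2 to compound 3 (0.07 log units; within the scatter) and thus no readable effect of swapping this ring for the open chain. Methyl in place of chloro on an aromatic carbon shows a 63-fold higher number from compound 1 to compound 3 (1.80 log units; beyond the scatter) with the dipropylamino chain held fixed, so this large step belongs to the aromatic group alone. Nothing available explains either step. From the compounds shown here alone, whether morpholine on the same chain, or a longer chain, would also leave the number within the scatter remains open. So does what fluoro or methoxy would give on that aromatic carbon.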